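This account rests on a few compounds, and the source may have more. Where it says the series, first, only, none or still open, it means among the compounds named here.

Measured so far:
Compound 1 `CC1CCN(C2CCN(S(=O)(=O)c3ccc(Br)c(Cl)c3)CC2)CC1`: > 5000 nM
Compound 2 `CCc1ccc(S(=O)(=O)N2CCC(N3CCC(C)CC3)CC2)cc1`: > 5000 nM

In an ADME assay on HCT-116 cells (Homo sapiens) for cytotoxicity, read by CellTiter-Glo, with a stated time of 72 h (a lower number here means a stronger inhibitor, a higher number a weaker inhibitor), compound 1 gives > 5000 nM, which is a limit of the assay and not a number. Compound 2 gives > 5000 nM, which is also a limit and not a number. Going by the values given here, compound 2 therefore has no exact value to start from, and the only other value beside it is a limit too. The evidence so far is short: the limit of > 5000 nM in this assay, at which 2 of the 2 values shown sit.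

Compound 3 `CC1CCN(C2CCN(S(=O)(=O)c3ccc(F)cc3F)CC2)CC1` keeps the core of compound 2 and changes one group, with 2,4-difluorophenyl in place of 4-ethylphenyl on a sulfonyl sulfur.

Among the compounds with values here, the only measured step, a step that the two limits leave unreadable from compound 1 to compound 2, changed a group at this same place, but it offers no size to carry over. With no measured size to go on, no step beyond the usual scatter is expected in this assay, and no direction can be argued. The estimated step is a step that the limit leaves unreadable from compound 2 to compound 3. For compound 3 the expected value is 6000 nM, with an estimated range from 2500 nM to 15000 nM.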

Compound 3, half-maximal inhibitory concentration: > 5000 nM
Compound 3: only a limit was reported; the forecaster's own chance of this, stated with the estimate: 85%; the middle value lies beyond the limit too.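

In this assay compound 3 gives > 5000 nM, which is a limit of the assay and not a number. The steps among compound 1, compound 2 and compound 3 therefore cannot be read. What stays open is whether changing the group on the sulfonyl sulfur moves the value in this assay at all, because these compounds all stop at the same limit: the limit of > 5000 nM in this assay, at which 3 of the 3 values shown sit.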